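The compounds below may be only part of what the source reports. "The series", "measured", "known", "first", "only" and "open" are said of these compounds alone.

Compound 1 `c1ccc(CCCNC2CCc3ccsc3CC2)cc1` gives 5.1 nM in an assay on membranes from liver for displacement of a labelled ligand from Sigma intracellular receptor 2 (Rattus norvegicus), read by scintillation counting, with a stated time of 120 min, in the presence of a further agent that is not named here; a higher number here means a weaker inhibitor, a lower number a stronger inhibitor.
Compound 2 `OCc1cc2c(s1)CCC(NCCCc1ccccc1)CC2` gives 30 nM in this assay.

Compound 2 stands at the higher of these two numbers. For the measured compounds named here, the single measured step, a 5.9-fold higher number from compound 1 to compound 2 (0.77 log units; beyond the scatter), placed a hydroxymethyl where compound 1 had only hydrogen. Compound 3 `Brc1cc2c(s1)CCC(NCCCc1ccccc1)CC2` differs from compound 2 by bromo in place of hydroxymethyl on an aromatic carbon. Going by the values given here, no measured step covers this exact exchange; the only step that bears on it is the removal of hydroxymethyl, which was modest. A step of similar size, back toward a lower number, is expected: a 3.8-fold lower number from compound 2 to compound 3 (0.57 log units; beyond the scatter). Compound 3 is therefore estimated at 8 nM, with a range from 2.5 nM to 25 nM.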

Compound 3, inhibition constant: 43 nM
Beside the measured number, compound 3's estimate is 5.4-fold (0.73 log units) below it; measured number outside the range, above it.
By their numbers in this assay, from the lowest: compound 1; then compounds 2 and 3 (each within the scatter of the next).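

Exchanging hydroxymethyl for bromo on this carbon next to the ring sulfur gives a 1.4-fold higher number from compound 2 to compound 3 (0.16 log units; within the scatter) in this assay and so does not separate the two groups, although only hydroxymethyl carries a hydrogen-bond donor and acceptor. Bromo in place of hydrogen gives an 8.4-fold higher number from compound 1 to compound 3 (0.93 log units; beyond the scatter) and so the rise over compound 1 is not peculiar to hydroxymethyl. No supporting data explain this result. From the compounds shown here alone, whether a single fluorine or a methyl would stay closer to compound 1, and how an amine or a carboxylic acid here would fare, remains open.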